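A few compounds are considered here, and "the series" means these few. Any claim that something is new, unique, unknown or untested is made for them only; others in the source may bear on it.

Of the compounds shown here, three of a shared core have been measured in an assay on membranes from CHO cells for displacement of a labelled ligand from adenosine receptor A1 (Homo sapiens), read by scintillation counting, with a stated time of 60 min, tested at 1 uM; a higher number here means more inhibition at the concentration tested (going by the name of the read-out), a lower number less inhibition. Compound 1 `CC1=C(C(=O)OCc2ccccc2)C(c2ccco2)NC(=O)N1` carries a benzyl ester and a furan-2-yl group, and in this assay compound 1 gives 36%. Compound 2 `COC(=O)C1=C(C)NC(=O)NC1c1ccoc1` has a methyl ester and a furan-3-yl group; in this assay compound 2 gives 8%. Compound 3 `COC(=O)C1=C(C)NC(=O)NC1c1cccs1` keeps the methyl ester and carries thiophen-2-yl; in this assay compound 3 gives 6%. Compound 3 stands at the foot of the three numbers, but its gap to compound 2 lies within the scatter, while compound 1 stands well above it, beyond the scatter.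

For the measured compounds named here, the only one-place step among them is a number 2 percentage points lower from compound 2 to compound 3 (within the scatter), which shows that exchanging the aromatic group on the saturated ring carbon does little here.

Compound 4 `CC1=C(C(=O)OC(C)(C)C)C(c2cccs2)NC(=O)N1` differs from compound 3 by tert-butyl in place of methyl on an oxygen next to a carbonyl group. Going by the values given here, no measured step changes the ester alone; compounds 1 and 2 differ in two places at once, so their values only hint that a larger ester can go with a higher number. On that thin ground, a modest rise is expected from compound 3 to compound 4, a number 9 percentage points higher from compound 3 to compound 4 (within the scatter), with a wide range. Compound 4 is estimated to give 15%, between 0% and 40%.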

Compound 4, a percentage reported as inhibition, at one concentration (the size of the read-out at that concentration, not a potency): 26%
The estimate for compound 4 lay 11 percentage points below the measured number; the range from low to high includes it.
By their numbers in this assay, from the lowest: compounds 3 and 2 (each within the scatter of the next); then compounds 4 and 1 (each within the scatter of the next).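

In this assay, tert-butyl in place of methyl on an oxygen next to a carbonyl group gives a number 20 percentage points higher from compound 3 to compound 4 (beyond the scatter), so a change in this one place, with thiophen-2-yl held fixed, moves the read-out by more than repeat measurements would. For the compounds shown here, the earlier one-place step changed only the aromatic group and gave a number 2 percentage points lower from compound 2 to compound 3 (within the scatter), so this is the first direct sign that the group on the ester oxygen matters, and the first that does not rest on compounds differing in two places. Nothing available here bears on why the number rises.

A single step cannot show whether the rise follows the size of the group, its branching or something else, and ethyl or isopropyl on the same oxygen, or a carboxylic acid in place of the ester, would help to separate these possibilities. As far as these compounds go, it also remains open whether the same exchange would have a similar effect with furan-2-yl or furan-3-yl in place of thiophen-2-yl, and these single-concentration percentages do not give a potency.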